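Second chloro on the aryl substituent of the core

The source may report more compounds than this note shows. Statements on the series, on what has been measured and on what is new or still open speak of the compounds shown alone.

Compound 1 `CCOC(=O)C12C(=O)OCC=C1COC2c1ccccc1` carries an unsubstituted aromatic ring on the shared core; in a functional assay on HeLa cells (Homo sapiens) for cytotoxicity, read by MTT assay (on this read-out lower numbers stand for stronger inhibition and higher numbers for weaker inhibition), compound 1 gives 12800 nM. Compound 2 `CCOC(=O)C12C(=O)OCC=C1COC2c1cccc(Cl)c1` carries chloro in place of hydrogen on an aromatic carbon. For compound 2 this assay reports only a limit, > 1000000 nM, and no number. The step of an at least 78-fold higher number from compound 1 to compound 2 (1.89 log units; beyond the scatter) is accordingly itself a bound, set by the limit of > 1000000 nM in this assay, at which 1 of the 2 values shown sits. Compound 3 `CCOC(=O)C12C(=O)OCC=C1COC2c1ccc(Cl)c(Cl)c1` differs from compound 2 by chloro in place of hydrogen on an aromatic carbon. For the measured compounds named here, the one measured step that bears on a chloro entering this ring is an at least 78-fold higher number from compound 1 to compound 2 (1.89 log units; beyond the scatter), and it points away from inhibition. Going by the values given here, nothing among the measured compounds suggests a return toward a measurable number once a second chloro enters. Compound 3 is therefore expected to give 1000000 nM, within 200000 nM to 5000000 nM, most probably reported again as a limit. The expected step of a number no higher from compound 2 to compound 3 (the limit leaves the size open) is none beyond the scatter.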

Compound 3, half-maximal inhibitory concentration: 72400 nM
Beside the measured number, compound 3's estimate is 14-fold (1.14 log units) above it; measured number outside the range, below it.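

In this assay the same change, chloro in place of hydrogen on an aromatic carbon, does not run in one direction on this ring: the step of an at least 13-fold lower number from compound 2 to compound 3 (1.14 log units; beyond the scatter) is opposite in sign to the step of an at least 78-fold higher number from compound 1 to compound 2 (1.89 log units; beyond the scatter). A chloro placed ortho to a chloro group and para to a large group thus brings back a measurable number, so the outcome of this change depends on what the ring already carries. The size of the new step is only a bound, set by a limit for compound 2: the limit of > 1000000 nM in this assay, at which 1 of the 3 values shown sits.

From the compounds shown here alone, it remains open whether a chloro at this place would shift the number on the unsubstituted ring of compound 1. Going by these compounds, it also remains open whether the return is tied to chloro, or would appear as well with a methoxy group or an amine at the same place.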